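This account rests on a few compounds, and the source may have more. Where it says the series, first, only, none or still open, it means among the compounds named here.

Working notes on the series built on the core of compound 1 `CCOC(=O)C1=C(NN=C(C(C)=O)C(C)=O)Nc2[nH]nc(C)c2C1c1ccc(N(C)C)cc1`. In a functional assay on HeLa cells (Homo sapiens) for inhibition, read by MTT assay, with a stated time of 48 h (a lower number here means a stronger inhibitor, a higher number a weaker inhibitor), compound 1 gives 17000 nM, compound 2 `CCOC(=O)C1=C(N/C=N/c2ccccn2)Nc2[nH]nc(C)c2C1c1ccc(N(C)C)cc1` gives 29200 nM and compound 3 `CCOC(=O)C(=NNC1=C(C(=O)OCC)C(c2ccc(N(C)C)cc2)c2c(C)n[nH]c2N1)C(=O)OCC` gives 83800 nM, the highest of the three numbers.

The next structure is compound 4 `CCOC(=O)C1=C(N)Nc2[nH]nc(C)c2C1c1ccc(N(C)C)cc1`. The change from compound 3 is a hydrogen atom in place of a group of 12 heavy atoms (7 carbon, 1 nitrogen, 4 oxygen; no ring), on an amine nitrogen: a hydrogen atom takes the place of the whole group on an amine nitrogen. The measured steps that bear on it are swaps at this same nitrogen. The step of a 1.7-fold higher number from compound 1 to compound 2 (0.23 log units; within the scatter) stays within the scatter, while a 4.9-fold higher number from compound 1 to compound 3 (0.69 log units; beyond the scatter) and a 2.9-fold higher number from compound 2 to compound 3 (0.46 log units; beyond the scatter) are modest. None of these steps removes the group outright, so they indicate a likely size but only weakly a direction. Compound 3 sits highest in both of the steps beyond the scatter, which favours a lower number for compound 4.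

A modest estimated step of a 2.4-fold lower number from compound 3 to compound 4 (0.38 log units; beyond the scatter) is expected in this assay. The expected value for compound 4 is 35000 nM, with an estimated range of 13000 nM to 95000 nM.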

Compound 4, half-maximal inhibitory concentration: 6220 nM
For compound 4 the middle estimate is 5.6-fold (0.75 log units) above the measured one, outside the stated range (below it).
By their numbers in this assay, from the lowest: compound 4; then compounds 1 and 2 (each within the scatter of the next); then compound 3.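

In this assay, for the compounds shown here, the earlier swaps at this amine nitrogen gave only a weak direction, but replacing each group outright with a hydrogen atom now lowers the number in all three cases, with no compound going against it: a 2.7-fold lower number from compound 1 to compound 4 (0.44 log units; beyond the scatter) and a 4.7-fold lower number from compound 2 to compound 4 (0.67 log units; beyond the scatter) and a 13-fold lower number from compound 3 to compound 4 (1.13 log units; beyond the scatter). Compound 4 is therefore the strongest inhibitor of the four, and the largest step comes from losing the group of 12 heavy atoms. No data shown account for these differences. As far as these compounds go, what remains open is whether a single methyl group on this nitrogen stays close to compound 4 or already moves towards compound 1. An acetyl group or a longer alkyl chain at the same nitrogen would show how quickly the number rises as the group grows.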